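A few compounds are considered here, and "the series" means these few. Any claim that something is new, unique, unknown or untested is made for them only; others in the source may bear on it.

The measure throughout is an ADME assay on HepG2 2.2.15 cells (Homo sapiens) for cytotoxicity; on this read-out higher numbers stand for lower toxicity in this test and lower numbers for higher toxicity in this test. Compound 1 `O=C(Nc1ncc(Cc2ccc(Br)cc2)s1)c1cccs1` gives in this assay a reading that is only a limit of the assay, > 50000 nM. Compound 2 `COCCNc1ncc(C(Oc2ccc3cc(Br)ccc3c2)c2ccc(Cl)cc2)s1` is reported in this assay as "not toxic" (no number reported), with no number attached. Of the two readings shown, one sits at a limit (the limit of > 50000 nM in this assay, at which 1 of the 2 values shown sits), and compound 2 stands at the other, likewise without a number. Compound 3 `Cc1noc(C)c1C(=O)Nc1ncc(C(Oc2ccc3cc(Br)ccc3c2)c2ccc(Cl)cc2)s1` has not yet been tested in this assay. It differs from compound 2 in one place: (3,5-dimethyl-1,2-oxazol-4-yl)carbonyl in place of 2-methoxyethyl on a nitrogen on an aromatic ring. Going by the values given here, no step between measured compounds exists, and neither compound 1 nor compound 2 has a number to set a step against, so the expectation for compound 3 is no change beyond the usual scatter of this assay, with the outcome most likely once more a limit. Compound 3 is therefore estimated at 50000 nM. For compound 3 the expected range runs from 20000 nM to 100000 nM.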

Compound 3, half-maximal cytotoxic concentration: "not toxic" (no number reported)
For compound 3 the study gives words and no number, and the estimate cannot be compared.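

Going by these compounds alone, compound 2 and compound 3 are both reported only in words, as "not toxic", so no step between them can be read. Left open is how toxic any compound shown truly is in this assay, with compound 1 giving only a limit: the limit of > 50000 nM in this assay, at which 1 of the 3 values shown sits.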